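From pyridin-4-yl to phenyl on the shared core

This account rests on a few compounds, and the source may have more. Where it says the series, first, only, none or still open, it means among the compounds named here.

Measured compounds:
- compound 1 `O=C(CN1CCN(c2nnc(Cc3ccncc3)c3ccccc23)CC1)Nc1cccc(F)c1` gives 4600 nM
- compound 2 `O=C(CN1CCN(c2nnc(Cc3ccncc3)c3ccccc23)CC1)Nc1ccc(F)c(C(F)(F)F)c1` gives 16000 nM
- compound 3 `O=C(CN1CCN(c2nnc(Cc3ccncc3)c3ccccc23)CC1)Nc1c(F)cccc1F` gives 54400 nM

All three were tested in a functional assay on A549 cells (Homo sapiens) for cytotoxicity, read by MTT assay, with a stated time of 72 h; on this read-out higher numbers stand for weaker inhibition and lower numbers for stronger inhibition. Among them compound 1 gives the lowest number: the nearest is a 3.5-fold higher number from compound 1 to compound 2 (0.54 log units; beyond the scatter) and the furthest a 12-fold higher number from compound 1 to compound 3 (1.07 log units; beyond the scatter), both beyond the scatter, and a 3.4-fold higher number from compound 2 to compound 3 (0.53 log units; beyond the scatter) separates the other two.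

Compound 4 `O=C(CN1CCN(c2nnc(Cc3ccccc3)c3ccccc23)CC1)Nc1cccc(F)c1` differs from compound 1 in a single place: phenyl in place of pyridin-4-yl on a saturated chain carbon bound to an aromatic carbon. Within the data shown here, every measured step so far concerns the ring on the amide-type nitrogen, while the (pyridin-4-yl)methyl arm stays the same in compounds 1, 2 and 3. Among the measured compounds shown here, no measured step therefore bears on the change from compound 1 to compound 4, and its effect in this assay is unknown from these data.

With nothing to indicate a direction, the expectation for compound 4 is a number close to that of compound 1, with a step no larger than the scatter, as expressed by a 1.1-fold higher number from compound 1 to compound 4 (0.04 log units; within the scatter). The estimate for compound 4 in this assay is 5000 nM, with a range from 1500 nM to 17000 nM to reflect the absence of any directly comparable step.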

Compound 4, half-maximal inhibitory concentration: 130000 nM
Estimate against measurement, compound 4: 26-fold (1.41 log units) below, outside the stated range (above it).
By their numbers in this assay, from the lowest: compound 1; then compound 2; then compound 3; then compound 4.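

In this assay, a 28-fold higher number from compound 1 to compound 4 (1.45 log units; beyond the scatter) shows that the (pyridin-4-yl)methyl arm matters greatly: this step is larger than a 12-fold higher number from compound 1 to compound 3 (1.07 log units; beyond the scatter), the largest change seen on the ring on the amide-type nitrogen. The change is small on paper, since pyridin-4-yl and phenyl are both six-membered aromatic rings with the same heavy-atom count and no net charge, and they differ only in that a carbon replaces the ring nitrogen and the hydrogen-bond acceptor counted on pyridin-4-yl is gone. That one exchange is enough to weaken the read-out strongly, but no measurement on hand explains why this happens.

As far as these compounds go, whether the position of the nitrogen in the ring counts, or only its presence, stays open, and pyridin-3-yl, pyridin-2-yl or pyrimidin-5-yl at this place would address that, as would a longer chain such as a 2-(pyridin-4-yl)ethyl arm. From the compounds shown here alone, it is also open whether benzyl in place of (pyridin-4-yl)methyl would have a similar effect alongside the 2,6-difluorophenyl or 4-fluoro-3-(trifluoromethyl)phenyl amides.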